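Azo-amide series: chloro in place of the nitro group

This account rests on a few compounds, and the source may have more. Where it says the series, first, only, none or still open, it means among the compounds named here.

Compound 3 `O=C(Nc1ccccc1[N+](=O)[O-])c1ccc(/N=N\c2c[nH]c3ccccc23)cc1` gives 101000 nM in a functional assay on MCF7 cells (Homo sapiens) for inhibition, read by MTT assay, with a stated time of 72 h (on this read-out higher numbers stand for weaker inhibition and lower numbers for stronger inhibition), which puts it at the low end of the three numbers measured, none of which is separated from another beyond the scatter. Compound 2 `Cc1cccc(NC(=O)c2ccc(/N=N\c3c[nH]c4ccccc34)cc2)c1C` gives 106000 nM, and compound 1 `O=C(Nc1ccccc1)c1ccc(/N=N\c2c[nH]c3ccccc23)cc1` gives 147000 nM. The steps of a 1.4-fold lower number from compound 1 to compound 2 (0.14 log units; within the scatter), a 1.5-fold lower number from compound 1 to compound 3 (0.16 log units; within the scatter) and a 1.0-fold lower number from compound 2 to compound 3 (0.02 log units; within the scatter) all stay within the scatter, so substitution on the amide-type nitrogen has so far left this assay unmoved. Compound 4 `O=C(Nc1ccccc1Cl)c1ccc(/N=N\c2c[nH]c3ccccc23)cc1` differs from compound 3 by chloro in place of nitro on an aromatic carbon. For the measured compounds named here, the steps that bear on this are a 1.5-fold lower number from compound 1 to compound 3 (0.16 log units; within the scatter), which brought the nitro in, and a 1.0-fold lower number from compound 2 to compound 3 (0.02 log units; within the scatter), which exchanged one ortho-substituted ring for another; both were within the scatter. Going by the values given here, no measured compound carries a chloro, so nothing distinguishes it from nitro here. The step expected from compound 3 to compound 4 is therefore none beyond the scatter, a 1.0-fold lower number from compound 3 to compound 4 (0.00 log units; within the scatter). The estimate for compound 4 is 100000 nM, within a range from 50000 nM to 200000 nM.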

Compound 4, half-maximal inhibitory concentration: 112000 nM
The estimate for compound 4 lay 1.1-fold (0.05 log units) below the measured number; low and high end bracket the measured number.
By their numbers in this assay, from the lowest: compounds 3, 2, 4 and 1 (each within the scatter of the next).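

In this assay, the exchange on an aromatic carbon ortho to a large group, where nitro leaves and chloro enters with a different count of heavy atoms and hydrogen-bond acceptors, gives a 1.1-fold higher number from compound 3 to compound 4 (0.04 log units; within the scatter), so the nitro is not needed to keep the number where it stands. Chloro in place of hydrogen gives a 1.3-fold lower number from compound 1 to compound 4 (0.12 log units; within the scatter), and 2-chlorophenyl in place of 2,3-dimethylphenyl gives a 1.1-fold higher number from compound 2 to compound 4 (0.02 log units; within the scatter), which extends the flat picture to a third substituted ring. Nothing measured independently of these numbers bears on this result.

Going by these compounds, all four compounds lie within the scatter of one another, so it remains open whether any substituent on this ring can move the number in this assay. An amine or a carboxylic acid at this position, a longer chain on the amide-type nitrogen and any change to the shared core all remain untested in the compounds shown.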